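The source may report more compounds than this note shows. Statements on the series, on what has been measured and on what is new or still open speak of the compounds shown alone.

Among the compounds with values here, compound 1 `CCCCCCCCCCNC[C@@H]1OC[C@H](N)[C@@H]1O` is the one compound here with a number of its own. In a functional assay on A549 cells (Homo sapiens) for antiproliferative activity, read by MTT assay, with a stated time of 72 h (a lower number here means a stronger inhibitor, a higher number a weaker inhibitor), compound 1 gives 47800 nM. Compound 2 `CCCCCCCCCCNC[C@@H]1OC[C@H](N)[C@H]1O` has the same atoms and bonds and differs only in the configuration as drawn. In this assay compound 2 reaches only a limit, > 128000 nM, which is a boundary of the measurement rather than a number. The step of an at least 2.6-fold higher number from compound 1 to compound 2 (0.42 log units; beyond the scatter) is a configuration step and is known only as a limit, as the limit of > 128000 nM in this assay, at which 1 of the 2 values shown sits, and the fact that compounds 1 and 2 differ only in the configuration as drawn show.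

Compound 3 `CCCCCCCCCCCCCCNC[C@@H]1OC[C@H](N)[C@@H]1O` keeps the configuration of compound 1 and changes the chain instead: butyl in place of hydrogen on a saturated chain carbon, ten or more bonds along the chain from an amine nitrogen. No measured step bears on lengthening the chain; the one step shown concerns configuration only, so nothing here tells how far a longer chain moves the number. The expectation for compound 3 is therefore a modest move toward a lower number, the step of a 2.4-fold lower number from compound 1 to compound 3 (0.38 log units; beyond the scatter) being estimated, with a wide range. Compound 3 is estimated at 20000 nM in this assay, between 5000 nM and 80000 nM.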

Compound 3, half-maximal inhibitory concentration: 2850 nM
Beside the measured number, compound 3's estimate is 7.0-fold (0.85 log units) above it; measured number outside the range, below it.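

Butyl in place of hydrogen on a saturated chain carbon gives a 17-fold lower number from compound 1 to compound 3 (1.22 log units; beyond the scatter) in this assay. Until now the only step shown was one of configuration, known only as a limit; this one has a measured number at both ends, and it shows that a change far out on the chain, with the configuration of compound 1 kept, can shift the result by a large margin, more than the configuration step could be shown to do. Nothing measured here says why adding to the chain moves the number this far.

With only one chain extension shown, two chain lengths cannot say whether a longer chain still would lower the number further, level off or reverse the trend, or whether a chain ending in an amine or a carboxylic acid would behave like the plain one. Going by these compounds, it also stays open whether the same butyl extension would bring the configuration of compound 2, whose value is only a limit, to a measurable number.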